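Coumarin-pyrazole imines: halophenoxy change at the outer ring

This account rests on a few compounds, and the source may have more. Where it says the series, first, only, none or still open, it means among the compounds named here.

Measured so far:
- compound 1 `Cc1nn(C)c(Oc2ccc(Br)cc2)c1/C=N\CCCCCOc1cc2oc(=O)cc(C)c2cc1Cl` — "not determined" (no result reported)
- compound 2 `Cc1nn(C)c(Oc2ccc(I)cc2)c1/C=N\CCCCCOc1cc2oc(=O)cc(C)c2cc1Cl` — > 25000 nM
- compound 3 `Cc1nn(C)c(Oc2ccc(F)cc2)c1/C=N\CCCCCCOc1cc2oc(=O)cc(C)c2cc1Cl` — 13500 nM

Among the compounds with values here, in a functional assay on SMMC-7721 cells (Homo sapiens) for antiproliferative activity, read by MTT assay, with a stated time of 72 h (on this read-out lower numbers stand for stronger inhibition and higher numbers for weaker inhibition), compound 3 gives 13500 nM, the only single number in the set. For compound 1, the 4-bromophenoxy member with the five-carbon chain, the entry reads "not determined" (no result reported). Compound 2 reaches only a limit of the assay, > 25000 nM, which is the limit of the limit of > 25000 nM in this assay, at which 1 of the 3 values shown sits, and not a number. Within the data shown here, compound 2 and compound 3 differ in both the halogen and the chain, so no single step between them is drawn; their two values show only that one falls at the limit while the other is a measured number.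

Compound 4 `Cc1nn(C)c(Oc2cccc(Br)c2)c1/C=N\CCCCCCOc1cc2oc(=O)cc(C)c2cc1Cl` keeps the six-carbon chain and the core of compound 3 and changes the outer ring: 3-bromophenyl in place of 4-fluorophenyl on an oxygen on an aromatic ring. Among the measured compounds shown here, no step of this kind has been measured, so a change within the usual scatter is expected, in no fixed direction, with some chance of landing at the limit. The expected step is a 1.1-fold higher number from compound 3 to compound 4 (0.05 log units; within the scatter). Compound 4 is estimated at 15000 nM, within 6000 nM to 40000 nM.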

Compound 4, half-maximal inhibitory concentration: 5080 nM
Beside the measured number, compound 4's estimate is 3.0-fold (0.47 log units) above it; the measured number lies below the stated range.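

In this assay, within the data shown here, 3-bromophenyl in place of 4-fluorophenyl on an oxygen on an aromatic ring gives the first readable step, a 2.7-fold lower number from compound 3 to compound 4 (0.42 log units; beyond the scatter). With the chain and the core held constant, this shows that the outer ring can move the number beyond the usual scatter, although the step is modest and both the halogen and its place on the ring change at once. Nothing at hand gives a reason for this step.

Among these compounds, the separate contributions of the bromine and of its place on the ring remain open, and no step to compound 1 or compound 2 can be read. Also open, as far as these compounds go, is how this position responds to a methoxy group or an amine, and whether the step holds on a longer chain.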